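Removing one trifluoromethyl from the acylated compound 3

This account rests on a few compounds, and the source may have more. Where it says the series, first, only, none or still open, it means among the compounds named here.

Compound 1 `O=C(Nc1cc(C(F)(F)F)cc(C(F)(F)F)c1)C1NCCc2ccccc21` is the parent of the set. In a functional assay on NUGC-3 cells (Homo sapiens) for inhibition, read by sulforhodamine B assay, with a stated time of 48 h (on this read-out lower numbers stand for stronger inhibition of growth and higher numbers for weaker inhibition of growth), compound 1 returns only a limit, > 10000 nM. Compound 2 `O=C(Nc1cccc(C(F)(F)F)c1)C1NCCc2ccccc21` differs from it by hydrogen in place of trifluoromethyl on an aromatic carbon. In this assay compound 2 likewise returns a limit, > 10000 nM. Their step is a step that the two limits leave unreadable from compound 1 to compound 2 because both sit at the limit of > 10000 nM in this assay, at which 2 of the 3 values shown sit. Among the compounds with values here, compound 3 `O=C(Nc1cc(C(F)(F)F)cc(C(F)(F)F)c1)C1c2ccccc2CCN1C(=O)c1ccc(Cl)cc1` differs from compound 1 by (4-chlorophenyl)carbonyl in place of hydrogen on an amine nitrogen in a ring; in this assay compound 3 gives 2830 nM, the only number in the set, a step of an at least 3.5-fold lower number from compound 1 to compound 3 (0.54 log units; beyond the scatter).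

Compound 4 `O=C(Nc1cccc(C(F)(F)F)c1)C1c2ccccc2CCN1C(=O)c1ccc(Cl)cc1` awaits measurement. It differs from compound 3 by hydrogen in place of trifluoromethyl on an aromatic carbon, the same kind of change as from compound 1 to compound 2, at a place described in the same words. That earlier step gave no readable size, so nothing carries over. A modest weakening is expected, a 1.8-fold higher number from compound 3 to compound 4 (0.25 log units; within the scatter), with a real chance of a limit instead of a number. Compound 4 is estimated at 5000 nM, within 2000 nM to 15000 nM.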

Compound 4, concentration for 50% growth inhibition: > 10000 nM
Compound 4: only a limit was reported; the forecaster's own chance of this, stated with the estimate: 35%; middle value at least 2.0-fold (0.30 log units) away from the limit.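

In this assay, the change from trifluoromethyl to hydrogen on the acylated core gives an at least 3.5-fold higher number from compound 3 to compound 4 (0.54 log units; beyond the scatter), and this size is only a bound, as the value for compound 4 is a limit. On the core of compound 1 the same change cannot be read, nor can the acylation step linking compound 2 and compound 4, as each pair sits at one limit: the limit of > 10000 nM in this assay, at which 3 of the 4 values shown sit.

The loss is therefore shown on the acylated core alone, and nothing shows whether the change has any effect, or one of similar size, on the core of compound 1.

Still open, from the compounds shown here alone, is whether a nitrile in place of that trifluoromethyl would retain the growth inhibition of compound 3. Also open, going by these compounds, is how an amine or a carboxylic acid in place of the chlorine of the 4-chlorophenyl group would read.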